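Urea aryl swap on a chloropyrazine series

The source may hold more compounds than are shown below. What is called first, only, known or untested is meant among the compounds shown, and "the series" means these compounds.

Measured so far:
compound 1, `O=C(Nc1cccc(CNc2nccnc2Cl)c1)Nc1ccccc1Cl`: 6680 nM
compound 2, `O=C(Nc1cccc(CNc2nccnc2Cl)c1)Nc1ccc(Cl)c(Cl)c1`: 5210 nM

Both compounds share one core and differ only in the aryl group on the urea nitrogen. In a functional assay on T-24 cells (Homo sapiens) for antiproliferative activity, read by MTT assay, with a stated time of 48 h (on this read-out lower numbers stand for stronger inhibition and higher numbers for weaker inhibition), compound 1 gives 6680 nM and compound 2 gives 5210 nM; the step of a 1.3-fold lower number from compound 1 to compound 2 (0.11 log units; within the scatter) leaves the two values within scatter of each other, so neither can be called the stronger. Compound 2 holds the lowest of the two numbers, with compound 1 as its nearest neighbour.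

Compound 3, `Cc1ccccc1NC(=O)Nc1cccc(CNc2nccnc2Cl)c1`, is not yet measured. It differs from compound 2 by 2-methylphenyl in place of 3,4-dichlorophenyl on an amide-type nitrogen. Going by the values given here, the only step that bears on it is the aryl swap from compound 1 to compound 2, which stayed within scatter, and compound 1 itself carries a small substituent on the same ring. A step of a 1.2-fold higher number from compound 2 to compound 3 (0.10 log units; within the scatter) is therefore expected, that is, no change beyond the scatter. For compound 3 the estimate is 6500 nM, in the range 3000 nM to 14000 nM.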

Compound 3, half-maximal inhibitory concentration: 13600 nM
Compound 3: the middle estimate sits 2.1-fold (0.32 log units) below what was measured, and the stated range covers the measured number.
By their numbers in this assay, from the lowest: compounds 2 and 1 (each within the scatter of the next); then compound 3.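

The aryl group on the urea nitrogen is not as indifferent in this assay as the first pair suggested: 2-methylphenyl in place of 3,4-dichlorophenyl gives a 2.6-fold higher number from compound 2 to compound 3 (0.42 log units; beyond the scatter) and so weakens inhibition modestly. Going by these compounds alone, the single change of methyl in place of chloro on an aromatic carbon gives a 2.0-fold higher number from compound 1 to compound 3 (0.31 log units; beyond the scatter) and also goes beyond the scatter, so this position distinguishes between these two small substituents. Compound 3 is therefore the weakest of the three, while compound 1 and compound 2 remain within the scatter of each other, and no evidence is available on what lies behind the shift.

The compounds shown leave open how an unsubstituted phenyl would compare on the same urea nitrogen. They also leave open whether a methoxy, fluoro or ethyl group in place of the methyl of compound 3 would follow chloro or methyl.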